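Swapping the aryl halide on a fused oxazole core

The source may report more compounds than this note shows. Statements on the series, on what has been measured and on what is new or still open speak of the compounds shown alone.

Compound 2, `Fc1ccccc1-c1nc2ccc(N3CCCCC3)nc2o1`, carries a 2-fluorophenyl group on the five-membered ring of its fused core and a piperidine on the pyridine side. In an assay on isolated protein for inhibition of Amine oxidase [flavin-containing] B (Homo sapiens), read by fluorescence, with a stated time of 1 h (a higher number here means a weaker inhibitor, a lower number a stronger inhibitor), compound 2 gives 665 nM. Going by the values given here, that is the only number available in this assay: compound 1, `c1ccc(-c2nc3ccc(N4CCCCCC4)nc3o2)cc1`, which differs by carrying a seven-membered azepane ring instead of the piperidine, has no result reported; in this assay compound 1 gives "not determined" (no result reported), so compound 2 stands alone and cannot be ranked against anything.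

The next compound, compound 3, `Clc1ccc(-c2nc3ccc(N4CCCCC4)nc3o2)cc1`, keeps the core and the piperidine and changes only the aromatic group attached to the five-membered ring: 4-chlorophenyl in place of 2-fluorophenyl on an aromatic carbon. Among the compounds with values here, no measured pair shows what this kind of exchange does here, so the expectation rests on a single starting point. A change that moves the halogen around the ring and swaps fluorine for chlorine could shift the inhibitory concentration in either direction; a modest gain in potency is expected, of about a 2.2-fold lower number from compound 2 to compound 3 (0.35 log units; beyond the scatter), though a result within the ordinary scatter would not be surprising. For compound 3 the expected value in this assay is 300 nM, with a plausible range from 60 nM to 1500 nM.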

Compound 3, half-maximal inhibitory concentration: 890 nM
Beside the measured number, compound 3's estimate is 3.0-fold (0.47 log units) below it; low and high end bracket the measured number.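

In this assay, going by these compounds alone, putting 4-chlorophenyl in place of 2-fluorophenyl on this aromatic carbon gives a 1.3-fold higher number from compound 2 to compound 3 (0.13 log units; within the scatter), the first measured step at this place on the core, and it does not separate the two compounds. Within the data shown here, two things differ at once in this pair, the kind of halogen and where it sits on the phenyl ring, so a shared reading shows only that these two groups are not told apart here; it does not show that each feature alone is without effect. No measurement at hand explains the result or says how either feature acts on its own.

From the compounds shown here alone, what remains open is how far this place responds to groups of a different kind, such as an unsubstituted phenyl with the piperidine kept, a phenyl carrying a methoxy group or a carboxylic acid, or a pyridine ring in place of the phenyl. The ring on the other side of the core is also unresolved, since compound 1 with its azepane gives "not determined" (no result reported) and so offers no comparison with the piperidine.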